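Fluorine pattern swap on the benzyl group of compound 2

The source may report more compounds than this note shows. Statements on the series, on what has been measured and on what is new or still open speak of the compounds shown alone.

Compound 2 `CCOC(=O)/C(O)=C/C(=O)c1cn(Cc2c(F)ccc(F)c2F)c2cccc(OC)c12` gives 40500 nM in an ADME assay on MT4 cells (Homo sapiens) for cytotoxicity, read by MTT assay (on this read-out higher numbers stand for lower toxicity in this test and lower numbers for higher toxicity in this test), the lowest of the three numbers measured, though within the scatter of compound 3 `COc1cccc2c1c(C(=O)/C=C(\O)C(=O)O)cn2Cc1c(F)ccc(F)c1F` at 49400 nM and of compound 1 `COc1cccc2c1c(C(=O)/C=C(\O)C(=O)O)cn2Cc1ccc(F)c(F)c1` at 71000 nM. Compound 4 `CCOC(=O)/C(O)=C/C(=O)c1cn(Cc2cc(F)c(F)c(F)c2)c2cccc(OC)c12` is unmeasured and differs from compound 2 by 3,4,5-trifluorophenyl in place of 2,3,6-trifluorophenyl on a saturated chain carbon bound to an aromatic nitrogen, a 3,4,5-trifluorophenyl in place of 2,3,6-trifluorophenyl on a saturated chain carbon bound to an aromatic nitrogen. Going by the values given here, the only step that bears on it is a 1.4-fold lower number from compound 1 to compound 3 (0.16 log units; within the scatter), another change of the fluorine pattern on the same group, which stayed within the scatter. Compound 4 is therefore expected to sit close to compound 2, at 45000 nM (range 20000 nM to 95000 nM), with an expected step of a 1.1-fold higher number from compound 2 to compound 4 (0.05 log units; within the scatter), none beyond the scatter.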

Compound 4, half-maximal cytotoxic concentration: 33400 nM
Compound 4: middle estimate off by 1.3-fold (0.13 log units), on the high side, within the range that was stated.
By their numbers in this assay, from the lowest: compounds 4, 2, 3 and 1 (each within the scatter of the next, the first and the last beyond it).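

The step from 2,3,6-trifluorobenzyl to 3,4,5-trifluorobenzyl gives a 1.2-fold lower number from compound 2 to compound 4 (0.08 log units; within the scatter) in this assay. Going by these compounds alone, this shows that, on a saturated chain carbon bound to an aromatic nitrogen, rearranging the three fluorines leaves the number within the scatter with the ethyl ester in place, whereas the earlier fluorine change was seen only with the free acid. Nothing measured here offers a reason for this.

Going by these compounds, it remains open whether a chlorine or a methoxy group on the benzyl ring, or an unsubstituted benzyl group, would behave the same way. On these data alone, an amide in place of the ethyl ester is equally open.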